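Amide variation in a sulfonylpiperazine series: working notes

The compounds below may be only part of what the source reports. "The series", "measured", "known", "first", "only" and "open" are said of these compounds alone.

Measured so far:
- compound 1, `CC(C(=O)N1CC2CC2C1)N1CCN(S(=O)(=O)c2ccc(C(C)(C)C)cc2)CC1`, in an ADME assay on HepG2 cells (Homo sapiens) for inhibition, with a stated time of 48 h (a higher number here means that more compound is needed for the effect, a lower number that less compound is needed), gives > 40000 nM, a limit of the assay
- compound 2, `CC(C(=O)N1CCC(F)(F)CC1)N1CCN(S(=O)(=O)c2ccc(C(C)(C)C)cc2)CC1`, in this assay gives > 40000 nM, a limit of the assay
- compound 3, `CC(C(=O)N1CCC(C)(C)CC1)N1CCN(S(=O)(=O)c2ccc(C(C)(C)C)cc2)CC1`, in this assay gives > 40000 nM, a limit of the assay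

Compound 3 therefore stands at a limit, not at a number, and the other two values shown are limits too; the position is summarised by the limit of > 40000 nM in this assay, at which 3 of the 3 values shown sit. Going by these compounds, the steps between the measured compounds cannot be read: a step that the two limits leave unreadable from compound 1 to compound 2, a step that the two limits leave unreadable from compound 1 to compound 3 and a step that the two limits leave unreadable from compound 2 to compound 3 all lie between two limits, so their size and direction are unknown.

Compound 4, `CC(C(=O)N(C)Cc1ccccc1)N1CCN(S(=O)(=O)c2ccc(C(C)(C)C)cc2)CC1`, is not yet measured. It differs from compound 3 by benzyl(methyl)amino in place of 4,4-dimethylpiperidin-1-yl on a carbonyl carbon. None of the three measured steps gives a readable size, so no step on the amide side has yet been shown to move the read-out off the limit. The expectation for compound 4 is that it stays at or near the same limit, with the estimated step of a number no higher from compound 3 to compound 4 (the limit leaves the size open) being no more than the scatter. Compound 4 is therefore estimated at 40000 nM, with a range from 15000 nM to 100000 nM, and most likely reported again as a limit rather than a number.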

Compound 4, half-maximal effective concentration: > 40000 nM
Compound 4 ended at the assay's limit (the forecaster's own chance of this, stated with the estimate: 80%); the middle value lies on the limit itself.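

In this assay compound 4 gives > 40000 nM, a limit of the assay. The steps to compound 4 from compound 1, compound 2 and compound 3 therefore cannot be read, as each lies between two limits: the limit of > 40000 nM in this assay, at which 4 of the 4 values shown sit.

The compounds shown leave open how these four amides compare in size of read-out, and whether any change on the carbonyl carbon brings the read-out off the limit.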